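Adding a hydroxymethyl group to compound 2

The compounds below may be only part of what the source reports. "The series", "measured", "known", "first", "only" and "open" are said of these compounds alone.

- Compound 1 `COc1ccccc1/C=C/[C@@](C)(/C=C/c1ccc(O)cc1)CCC=C(C)C` gives 10% in growth inhibition
- Compound 2 `COc1ccc(/C=C/[C@@](C)(/C=C/c2ccc(O)cc2)CCC=C(C)C)cc1` gives 40% in growth inhibition
- Compound 3 `CC(C)=CCCC(C)(/C=C/c1ccc(O)cc1)/C=C/c1ccc(O)cc1` gives 33% in growth inhibition

All three compounds were tested in a functional assay on A549 cells (Homo sapiens) for inhibition, with a stated time of 48 h, tested at 50 uM (on this read-out lower numbers stand for less inhibition of growth and higher numbers for more inhibition of growth at the one concentration tested), and share one core. Compound 2 sits at the top end of the three numbers, level with compound 3 within the scatter and clearly above compound 1. The next compound to be tested, compound 4 `COc1ccc(/C=C/[C@@](C)(/C=C/c2ccc(O)cc2)CCC=C(C)C)cc1CO`, differs from compound 2 by a single change: hydroxymethyl in place of hydrogen on an aromatic carbon. The new group is ortho to a methoxy group.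

Going by the values given here, two measured steps bear on this change, and both concern the ring that carries it. Shifting the methoxy group on that ring gave a number 30 percentage points higher from compound 1 to compound 2 (beyond the scatter), so a change here can matter. Replacing methyl with hydrogen on its oxygen gave a number 7 percentage points lower from compound 2 to compound 3 (within the scatter), which stays within the scatter. Among the compounds with values here, neither step adds a hydroxymethyl group, and no measured compound carries one, so the evidence is thin. A small change is the most likely outcome, with no step beyond the scatter, though a larger one in either direction remains possible. The estimate amounts to an expected a number 5 percentage points lower from compound 2 to compound 4 (within the scatter) in this assay for this pair. For compound 4 the expected value is 35%, with an estimated range from 15% to 55% in this read-out.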

Compound 4, percent growth inhibition at one concentration: 41%
Compound 4: middle estimate off by 6 percentage points, on the low side; the range from low to high includes it.
By their numbers in this assay, from the lowest: compound 1; then compounds 3, 2 and 4 (each within the scatter of the next).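

In this assay, hydroxymethyl in place of hydrogen on this aromatic carbon gives a number 1 percentage points higher from compound 2 to compound 4 (within the scatter), so the change cannot be told apart from the ordinary spread of repeated measurements. Going by these compounds alone, this shows that the carbon ortho to a methoxy group can carry a hydroxymethyl group with no detectable loss of growth inhibition at the one concentration tested, something no earlier compound could show. The same ring responded clearly to a different alteration, the move of the methoxy group that gave a number 30 percentage points higher from compound 1 to compound 2 (beyond the scatter), so not every change on this ring behaves alike, and nothing shown here explains the difference between these two results.

As far as these compounds go, it remains open whether this carbon would tolerate other groups in the same way, such as an amine, a carboxylic acid or a longer chain ending in a hydroxyl group. Because each compound was read at a single concentration, the compounds shown also leave open whether compound 2 and compound 4 would still match across a full range of concentrations.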